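This account rests on a few compounds, and the source may have more. Where it says the series, first, only, none or still open, it means among the compounds named here.

- Compound 1 `O=C(CN(C(=O)c1ccc(-c2ccccn2)cc1)C1CCCCC1)Nc1cc(F)cc(F)c1`: 3.7
- Compound 2 `COCC(C)N(CC(=O)Nc1cc(F)cc(F)c1)C(=O)c1ccc(-c2ccccn2)cc1`: 3

In a physicochemical assay for lipophilicity (a lower number here means a more polar compound, a higher number a more lipophilic compound), compound 2 gives 3, the lower of the two numbers, while compound 1 gives 3.7. Compound 3 `CCC(COC)N(CC(=O)Nc1cc(F)cc(F)c1)C(=O)c1ccc(-c2ccccn2)cc1` differs from compound 2 by methyl in place of hydrogen on a saturated chain carbon, two bonds along the chain from an amide-type nitrogen. Within the data shown here, the only measured step that bears on this is a number 0.70 log units lower from compound 1 to compound 2 (beyond the scatter), with 1-(methoxymethyl)ethyl in place of cyclohexyl on an amide-type nitrogen. It does not test a methyl directly, but extending that same chain should undo part of this step. The expected change is a number 0.40 log units higher from compound 2 to compound 3 (beyond the scatter). For compound 3 the estimate is 3.4, with an expected range of 3.1 to 3.7.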

Compound 3, distribution coefficient: 3.3
The estimate for compound 3 lay 0.10 log units above the measured number, within the range that was stated.
By their numbers in this assay, from the lowest: compounds 2 and 3 (each within the scatter of the next); then compound 1.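

In this assay, methyl in place of hydrogen at this saturated chain carbon gives a number 0.30 log units higher from compound 2 to compound 3 (within the scatter) and so leaves compound 2 and compound 3 indistinguishable. The other comparison gives a number 0.40 log units lower from compound 1 to compound 3 (beyond the scatter) with 1-(methoxymethyl)propyl in place of cyclohexyl, so the gap to compound 1 stays beyond the scatter even with the added methyl. No supporting data are available to explain either result.

Still open, as far as these compounds go, is whether a longer chain at this carbon would separate from compound 2. Also open, from the compounds shown here alone, is how an amine in place of the methoxy group would read in this assay here.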